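This account rests on a few compounds, and the source may have more. Where it says the series, first, only, none or still open, it means among the compounds named here.

For the measured compounds named here, compound 3, `CC(C)c1cccc(C(C)C)c1NC(=O)NCC1(c2cccc(C(=O)O)c2)CCCC1`, stands at the top of the three numbers known in an assay on microsomes for inhibition of acyl-CoA:cholesterol acyltransferase (Oryctolagus cuniculus); on this read-out lower numbers stand for stronger inhibition and higher numbers for weaker inhibition: it gives 620 nM. Compound 1, `Cc1ccccc1C1(CNC(=O)Nc2c(C(C)C)cccc2C(C)C)CCCC1`, gives 17 nM in this assay, and compound 2, `Cc1ccc(C2(CNC(=O)Nc3c(C(C)C)cccc3C(C)C)CCCC2)cc1`, gives 25 nM. The exchange of 2-methylphenyl for 4-methylphenyl gave a 1.5-fold higher number from compound 1 to compound 2 (0.17 log units; within the scatter), whereas a 36-fold higher number from compound 1 to compound 3 (1.56 log units; beyond the scatter) and a 25-fold higher number from compound 2 to compound 3 (1.39 log units; beyond the scatter) marked the arrival of the 3-carboxyphenyl group.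

Compound 4, `CC(C)c1cccc(C(C)C)c1NC(=O)NCC1(c2ccc(C(=O)O)cc2)CCCC1`, differs from compound 3 only in that (4-carboxyphenyl in place of 3-carboxyphenyl on a saturated ring carbon). Going by the values given here, the step that bears most directly on this change is the one from compound 1 to compound 2, where a methylphenyl group with a different substitution pattern was exchanged on the same saturated ring carbon and a 1.5-fold higher number from compound 1 to compound 2 (0.17 log units; within the scatter) resulted. The large steps to compound 3 concern the arrival of the carboxy group itself, which both compound 3 and compound 4 carry, so they give no guidance on the direction here. Among the compounds with values here, with only one comparable exchange on record, and that one within the scatter, no step beyond the scatter in this assay is expected from compound 3 to compound 4. Compound 4 is therefore estimated at 600 nM, with a range from 200 nM to 1800 nM, which means an expected step of a 1.0-fold lower number from compound 3 to compound 4 (0.01 log units; within the scatter).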

Compound 4, half-maximal inhibitory concentration: 3100 nM
Compound 4: the middle estimate sits 5.2-fold (0.71 log units) below what was measured; measured number outside the range, above it.
By their numbers in this assay, from the lowest: compounds 1 and 2 (each within the scatter of the next); then compound 3; then compound 4.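

In this assay the place of the carboxy group on the phenyl ring matters: 4-carboxyphenyl in place of 3-carboxyphenyl on the saturated ring carbon gave a 5.0-fold higher number from compound 3 to compound 4 (0.70 log units; beyond the scatter) and so moved the number further up. For the compounds shown here, the one earlier exchange of substitution pattern, between the two methylphenyl groups, had given a 1.5-fold higher number from compound 1 to compound 2 (0.17 log units; within the scatter) and stayed within the scatter, so the methyl pair did not carry over to the carboxy pair. Set against 4-methylphenyl, the 4-carboxyphenyl group gave a 120-fold higher number from compound 2 to compound 4 (2.09 log units; beyond the scatter) and set against 2-methylphenyl it gave a 180-fold higher number from compound 1 to compound 4 (2.26 log units; beyond the scatter), which makes the price of the carboxy group larger here than in compound 3, and nothing at hand says why the two carboxyphenyl groups part in this way.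

The compounds shown leave open where a 2-carboxyphenyl group on the same saturated ring carbon would fall in this order. They also leave open whether a methyl ester or a primary amide in place of the carboxy group would show the same dependence on its place on the phenyl ring.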